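This account rests on a few compounds, and the source may have more. Where it says the series, first, only, none or still open, it means among the compounds named here.

Of the compounds shown here, three have been measured in an assay on HEK293 cells for positive allosteric modulation of metabotropic glutamate receptor 3 (Rattus norvegicus), read by thallium flux, with a stated time of 2.5 min; on this read-out higher numbers stand for larger maximal responses and lower numbers for smaller maximal responses. Compound 1 `Cc1c(OCCCCOc2ccc(F)c(C(=O)O)c2)ccc(C(=O)CC(C)(C)C)c1O` gives 102%. Compound 2 `COc1cc(C(=O)O)ccc1OCCCCOc1ccc(C(=O)CC(C)(C)C)c(O)c1C` gives 109% in this assay; the difference between the core of compound 1 and the core of compound 2 is not broken down here. Compound 3 `CC(=O)c1ccc(OCCCCOc2ccc(F)c(C(=O)O)c2)c(C)c1O` gives 16.8% in this assay. Compound 3 is compound 1 after a single change, (hydrogen in place of tert-butyl on a saturated chain carbon bound to a carbonyl carbon), and that change made a step of a number 85.2 percentage points lower from compound 1 to compound 3 (beyond the scatter).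

Compound 4 `COc1cc(C(=O)O)ccc1OCCCCOc1ccc(C(C)=O)c(O)c1C` has not yet been measured. It is compound 2 after the same change, (hydrogen in place of tert-butyl on a saturated chain carbon bound to a carbonyl carbon), made at the same place. For the measured compounds named here, since the only measured example of this change is the step of a number 85.2 percentage points lower from compound 1 to compound 3 (beyond the scatter), a fall of similar size is expected from compound 2 to compound 4, so the expected step is a number 85 percentage points lower from compound 2 to compound 4 (beyond the scatter). That expectation rests on one measured pair alone, and nothing else among the compounds shown speaks for or against it. Compound 4 is therefore estimated to give 24% in this assay, with the expected range running from 10% to 45%.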

Compound 4, largest response reached (reported as percent of maximum), in percent of the reference or control that the assay uses: 26.3%
Beside the measured number, compound 4's estimate is 2.3 percentage points below it, within the range that was stated.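

In this assay, putting hydrogen in place of tert-butyl, which turns the neopentylcarbonyl group into acetyl, gave a step of a number 82.7 percentage points lower from compound 2 to compound 4 (beyond the scatter). On the core of compound 2 the change therefore did much the same as it did on the core of compound 1, so in this small set its effect carried from one core to the other: the same change on two cores in this assay, a number 85.2 percentage points lower (beyond the scatter) from compound 1 to compound 3 and a number 82.7 percentage points lower (beyond the scatter) from compound 2 to compound 4, 2.5 percentage points apart, within the scatter of two such steps. For the compounds shown here, this is still only two cores, so it does not show that the step would keep its size on a third core, and it does not explain why the maximal response falls.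

The compounds shown give only the two ends of the change, tert-butyl and hydrogen, so it remains open how the response behaves with groups of intermediate size at that place, such as an ethyl, an isopropyl or a cyclopropyl group. As far as these compounds go, whether a larger group, such as a cyclohexyl ring or a longer chain, would hold the response at the level of the tert-butyl compounds is also open.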